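Half-life series: tert-butyl in place of tert-butoxycarbonyl

The source may hold more compounds than are shown below. What is called first, only, known or untested is meant among the compounds shown, and "the series" means these compounds.

Measured so far:
compound 1 `CC(C)N1CC(=O)N=C1N/C(=N\C(=O)C(C)(C)C)Nc1ccc(Cl)c(Cl)c1`: > 1 h
compound 2 `CN1CC(=O)N=C1N/C(=N\C(=O)OC(C)(C)C)Nc1ccc(Cl)c(Cl)c1`: < 0.167 h
compound 3 `CC(C)N1CC(=O)N=C1N/C(=N\C(=O)OC(C)(C)C)Nc1ccc(Cl)c(Cl)c1`: 0.263 h

Within the data shown here, in an in vivo ADME assay on the whole organism for metabolic stability, with Mus musculus as the target, read by LC-MS, at a dose of 160 mg/kg by the oral route (a higher number here means that the compound lasts longer, a lower number that the compound disappears faster), compound 3 is the only compound with a plain number. Compound 1 sits at a limit, (the limit of > 1 h in this assay, at which 1 of the 3 values shown sits). Compound 2 sits at a limit too, (the limit of < 0.167 h in this assay, at which 1 of the 3 values shown sits). Two steps are known. From compound 1 to compound 3 the change is tert-butoxy in place of tert-butyl on a carbonyl carbon, and the number falls: an at least 3.8-fold lower number from compound 1 to compound 3 (0.58 log units; beyond the scatter). From compound 2 to compound 3 the change is isopropyl in place of methyl on an amine nitrogen in a ring: an at least 1.5-fold higher number from compound 2 to compound 3 (0.19 log units; that floor lies within the scatter), a floor that stays within the scatter.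

Compound 4 `CC(C)N1CC(=O)N=C1N/C(=N\C(C)(C)C)Nc1ccc(Cl)c(Cl)c1` differs from compound 3 in one place: tert-butyl in place of tert-butoxycarbonyl on a double-bonded nitrogen. The step from compound 1 to compound 3 is the one that bears on it, since both touch the group carried by the double-bonded nitrogen; that step is at least modest, and compound 4 goes further in removing the carbonyl and the oxygen altogether, so a step upward in this assay of at least modest size is expected for compound 4, as a 3.4-fold higher number from compound 3 to compound 4 (0.53 log units; beyond the scatter). Compound 4 is accordingly expected to give 0.9 h, within 0.3 h to 2.5 h.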

Compound 4, half-life: 0.0287 h
Compound 4: the middle estimate sits 31-fold (1.50 log units) above what was measured; the whole stated range lies above it.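

At this position the carbonyl counts as well as the group beyond it: with tert-butyl in place of tert-butoxycarbonyl on the double-bonded nitrogen, this assay gives a 9.2-fold lower number from compound 3 to compound 4 (0.96 log units; beyond the scatter). Among these compounds, the earlier step compared only two groups that both keep the carbonyl, and it left open whether a group without one would lie above or below them, whereas the step against (tert-butyl)carbonyl now reads an at least 34-fold lower number from compound 1 to compound 4 (1.54 log units; beyond the scatter), a floor and not a measured size, since it rests on a limit of the assay for compound 1. Among the isopropyl compounds, both carbonyl-bearing groups therefore keep a longer half-life than tert-butyl alone, with none of the three going against this, but nothing shown gives a reason for the fall.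

Open, going by these compounds, is whether an acetyl, a carboxylic acid or a plain hydrogen on the double-bonded nitrogen would fall with the carbonyl-bearing compounds or with compound 4. Also open, on these data alone, is whether the fall seen on leaving the carbonyl holds when methyl or a longer chain replaces isopropyl on the amine nitrogen in the ring.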